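Ether side chain variation at the aryl oxygen

The source may report more compounds than this note shows. Statements on the series, on what has been measured and on what is new or still open speak of the compounds shown alone.

Measured so far:
compound 1 `CCC(C)COc1cccc2ccc(N)nc12`: 36 nM
compound 2 `Nc1ccc2cccc(OCCC3CC3)c2n1`: 492 nM
compound 3 `Nc1ccc2cccc(OCC3CC3)c2n1`: a limit only, > 2000 nM

In an assay on cells with melanin-concentrating hormone receptor 1 (Homo sapiens) as the target, read by radioligand binding (a lower number here means a stronger inhibitor, a higher number a weaker inhibitor), compound 1 holds the lowest of the two numbers given, and the nearest is a 14-fold higher number from compound 1 to compound 2 (1.14 log units; beyond the scatter). For compound 3 this assay reports only a limit, (the limit of > 2000 nM in this assay, at which 1 of the 3 values shown sits). Compound 4 `Nc1ccc2cccc(OCC3CCCO3)c2n1` carries oxolan-2-yl in place of sec-butyl on a saturated chain carbon bound to an oxygen on an aromatic ring. Within the data shown here, the steps that bear on this change are a 14-fold higher number from compound 1 to compound 2 (1.14 log units; beyond the scatter) and an at least 55-fold higher number from compound 1 to compound 3 (1.74 log units; beyond the scatter), both large and beyond the scatter, with an at least 4.0-fold higher number from compound 2 to compound 3 (0.60 log units; beyond the scatter) between the two ring-bearing chains. Oxolan-2-yl, like cyclopropyl, is a ring sitting on the saturated chain carbon bound to an oxygen on the aromatic ring, so a weaker inhibitor than compound 1 is expected, an 11-fold higher number from compound 1 to compound 4 (1.05 log units; beyond the scatter). Compound 4 is estimated at 400 nM, within 100 nM to 2000 nM.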

Compound 4, half-maximal inhibitory concentration: > 2000 nM
Compound 4 gave a limit, no number; the forecaster's own chance of this, stated with the estimate: 15%; middle value at least 5.0-fold (0.69 log units) away from the limit.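

In this assay, compound 4 is a limit, not a number: the limit of > 2000 nM in this assay, at which 2 of the 4 values shown sit.

Placing oxolan-2-yl, with its one hydrogen-bond acceptor, at this position gives an at least 55-fold higher number from compound 1 to compound 4 (1.74 log units; beyond the scatter), and also an at least 4.0-fold higher number from compound 2 to compound 4 (0.60 log units; beyond the scatter), so this ring does not reach the level of the sec-butyl compound. The step from compound 3 to compound 4 cannot be read.

The compounds shown do not separate the effect of the ring from that of its oxygen. A cyclopentyl ring in place of oxolan-2-yl, or an open methoxyethyl chain in place of 2-methylbutyl, would bear on that question.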